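A few compounds are considered here, and "the series" means these few. Any claim that something is new, unique, unknown or untested is made for them only; others in the source may bear on it.

Within the data shown here, in a functional assay on MCF7 cells (Homo sapiens) for antiproliferative activity, read by CellTiter-Glo, with a stated time of 5 days (a higher number here means a weaker inhibitor, a lower number a stronger inhibitor), compound 1 `CC/C(=C(/c1ccc(/C=C/C(=O)O)cc1)c1ccc2c(cnn2C)c1)c1ccccc1` gives 300 nM and compound 2 `CC/C(=C(/c1ccc(/C=C/C(=O)O)cc1)c1ccc2nccn2c1)c1ccccc1` gives 170 nM so the only two numbers at hand lie within the scatter of each other. Compound 3 `CC/C(=C(/c1ccc(/C=C/C(=O)O)cc1)c1ccn2nncc2c1)c1ccccc1` has not yet been measured. Its difference from compound 1 is a group of 9 heavy atoms (6 carbon, 3 nitrogen; one five-membered aromatic ring with 3 hetero atoms, one six-membered aromatic ring with 1 hetero atom) in place of a group of 10 heavy atoms (8 carbon, 2 nitrogen; one five-membered aromatic ring with 2 hetero atoms, one six-membered aromatic ring of carbon only), on a double-bonded chain carbon bound to an aromatic carbon and a double-bonded chain carbon and it falls on a double-bonded chain carbon bound to an aromatic carbon and a double-bonded chain carbon. Among the measured compounds shown here, the one measured step that bears on it is a 1.8-fold lower number from compound 1 to compound 2 (0.25 log units; within the scatter) and this step, made at the same place, also brings in a six-membered aromatic ring with 1 hetero atom. It stays within the scatter, so no step beyond the scatter is expected in this assay here. For the measured compounds named here, the data hold no measured compound with a five-membered aromatic ring with 3 hetero atoms, so this expectation rests on thin support. The expected step is a 1.2-fold lower number from compound 1 to compound 3 (0.08 log units; within the scatter) and no more than that. For compound 3 the estimated value is 250 nM with an expected range from 100 nM to 650 nM at its upper end.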

Compound 3, half-maximal inhibitory concentration: > 500 nM
Compound 3 gave a limit, no number (the forecaster's own chance of this, stated with the estimate: 3%); middle value at least 2.0-fold (0.30 log units) from the limit.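

Compound 3 gave a limit and not a number in this assay: the limit of > 500 nM in this assay, at which 1 of the 3 values shown sits.

This shows that changes at this double-bonded chain carbon are not all silent, since the change of one fused pair of aromatic rings for another gives an at least 2.9-fold higher number from compound 2 to compound 3 (0.46 log units; beyond the scatter). Both groups in that step hold a six-membered aromatic ring with 1 hetero atom, so that ring alone does not keep the number low; the step differs in the five-membered aromatic ring, with 3 hetero atoms in place of 2. The other step is less telling: it is an at least 1.6-fold higher number from compound 1 to compound 3 (0.22 log units; that floor lies within the scatter), and so it does not settle the change from 1-methyl-1H-indazol-5-yl.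

Going by these compounds, how far the true number of compound 3 lies past its limit remains open. So does how a smaller group at this place, such as a single pyridyl ring, would compare.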